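Notes on the step from compound 2 to compound 3

The compounds below may be only part of what the source reports. "The series", "measured", "known", "first", "only" and "open" are said of these compounds alone.

Measured in an ADME assay on microsomes from liver (Canis lupus familiaris) for metabolic stability; a lower number here means that the compound disappears faster, a higher number that the compound lasts longer:
- Compound 1 `Nc1nc(NCCNc2ncc(-c3ncc[nH]3)c(-c3cc(F)ccc3Cl)n2)ccc1[N+](=O)[O-]`: > 0.5 h
- Compound 2 `Nc1nc(NCCNc2ncc(-c3ncc[nH]3)c(-c3ccc(F)cc3Br)n2)ccc1[N+](=O)[O-]`: > 0.5 h

Compound 2 gives only a limit of the assay, > 0.5 h, and no number. Compound 1 likewise gives only a limit, > 0.5 h. For the measured compounds named here, the series so far therefore rests on (the limit of > 0.5 h in this assay, at which 2 of the 2 values shown sit).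

Compound 3 `Nc1nc(NCCNc2ncc(-c3ncc[nH]3)c(-c3ccc(F)cc3C(F)(F)F)n2)ccc1[N+](=O)[O-]` is the next analogue: trifluoromethyl in place of bromo on an aromatic carbon. The trifluoromethyl group sits ortho to a large group and meta to a fluoro group.

Going by the values given here, the only measured step is a step that the two limits leave unreadable from compound 1 to compound 2. It is a different exchange and gives no size to carry over. With no size or direction to draw on, no change beyond the usual scatter is expected in this assay, and another limit is likely. The expected step is a step that the limit leaves unreadable from compound 2 to compound 3. The estimate for compound 3 is 0.8 h, with an expected range of 0.4 h to 2 h.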

Compound 3, half-life: > 0.5 h
Compound 3 was reported as a limit; the forecaster's own chance of this, stated with the estimate: 65%; the middle value is on the limit's open side.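

Compound 3 gives only a limit, > 0.5 h, in this assay. No step among compound 1, compound 2 and compound 3 can be read, and the series still rests on a single limit: the limit of > 0.5 h in this assay, at which 3 of the 3 values shown sit.

What stays open is the actual half-life of each of these compounds, and whether the exchanges on the aromatic carbon change it at all.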